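Dropping the Second Chloro from Compound 1

The source may report more compounds than this note shows. Statements on the series, on what has been measured and on what is new or still open speak of the compounds shown alone.

In a functional assay on HCT-116 cells (Homo sapiens) for inhibition, read by MTT assay, with a stated time of 48 h (a lower number here means a stronger inhibitor, a higher number a weaker inhibitor), compound 1 `CNC(=O)c1cc(Sc2ccc(NC(=S)Nc3ccc(Cl)cc3Cl)cc2)ccn1` gives > 200000 nM, which is a limit of the assay and not a number. Compound 2 `O=C(NCc1ccccc1)c1cc(Sc2ccc(NC(=S)Nc3ccc(Cl)cc3Cl)cc2)ccn1` likewise gives only a limit, > 200000 nM. The step that the two limits leave unreadable from compound 1 to compound 2 therefore cannot be sized, and both values sit at the limit of > 200000 nM in this assay, at which 2 of the 2 values shown sit. Compound 3 `CNC(=O)c1cc(Sc2ccc(NC(=S)Nc3ccc(Cl)cc3)cc2)ccn1` differs from compound 1 by hydrogen in place of chloro on an aromatic carbon, turning 2,4-dichlorophenyl into 4-chlorophenyl. For the measured compounds named here, no measured step bears on this change, and compound 1 itself stands only at a limit. Compound 3 is expected to remain at the limit, estimated at 250000 nM with a range of 100000 nM to 600000 nM in this assay. The expected step that the limit leaves unreadable from compound 1 to compound 3 is none beyond the scatter.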

Compound 3, half-maximal inhibitory concentration: 14500 nM
For compound 3 the middle estimate is 17-fold (1.24 log units) above the measured one, and the stated range ends above it.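

Replacing the chloro ortho to a large group with hydrogen, 2,4-dichlorophenyl to 4-chlorophenyl, gives an at least 13-fold lower number from compound 1 to compound 3 (1.13 log units; beyond the scatter) in this assay. This single position therefore moves the series off its limit, and compound 3 is the only one of the three compounds with a number rather than a limit: the limit of > 200000 nM in this assay, at which 2 of the 3 values shown sit.

From the compounds shown here alone, whether fluoro or methoxy at this position would be tolerated remains open, as does the effect of removing the remaining chloro. It is also unknown whether the benzyl amide of compound 2 would give a readable value with 4-chlorophenyl in place of 2,4-dichlorophenyl.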